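Hydroxy for Methyl on the Pendant Ring

The source may hold more compounds than are shown below. What is called first, only, known or untested is meant among the compounds shown, and "the series" means these compounds.

Three compounds built on a shared core have been run in an assay on HEK293 cells for inhibition of transient receptor potential cation channel subfamily M member 8 (Homo sapiens), read by FLIPR, with stated times of 5 min and 3 min; on this read-out higher numbers stand for weaker inhibition and lower numbers for stronger inhibition. Compound 1 `CCn1nnc(-c2sc(-c3ccccc3O)nc2O)n1` gives 24 nM in this assay. Compound 3 `CCn1nnc(-c2sc(-c3ccccc3C)nc2O)n1` gives 60 nM in this assay, and compound 2 `CCn1nnc(-c2sc(-c3cccc(C)c3)nc2O)n1` gives 369 nM in this assay, the highest number of the three. Compound 2 and compound 3 have the same atoms joined differently; the difference between the two cores is not broken down here, and the two values alone show compound 2 standing well above compound 3.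

One measured step joins compound 3 and compound 1: hydroxy in place of methyl on an aromatic carbon This change brought a 2.5-fold lower number from compound 3 to compound 1 (0.40 log units; beyond the scatter).

Compound 4 `CCn1nnc(-c2sc(-c3cccc(O)c3)nc2O)n1` has not yet been measured. It stands to compound 2 in the same kind of change: hydroxy in place of methyl on an aromatic carbon The two places are not the same word for word: in compound 1 the hydroxy sits ortho to a large group, whereas in compound 4 it sits meta to a large group, so this is the same kind of change rather than the same change. Resting on a 2.5-fold lower number from compound 3 to compound 1 (0.40 log units; beyond the scatter), compound 4 is expected to show a 2.1-fold lower number from compound 2 to compound 4 (0.31 log units; beyond the scatter), with the range kept wide since the place is not the same. Compound 4 is therefore estimated at 180 nM in this assay, between 60 nM and 500 nM.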

Compound 4, half-maximal inhibitory concentration: 239 nM
For compound 4 the middle estimate is 1.3-fold (0.12 log units) below the measured one, and the stated range covers the measured number.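

In this assay, hydroxy in place of methyl, here meta to a large group, gives a 1.5-fold lower number from compound 2 to compound 4 (0.19 log units; within the scatter), so this step taken alone does not set compound 4 apart from compound 2. Set beside the same change on the core of compound 1, the step gives no sign that the outcome depends on the core, and the two sizes cannot be told apart: the same change on two cores in this assay, a 2.5-fold lower number (0.40 log units; beyond the scatter) from compound 3 to compound 1 and a 1.5-fold lower number (0.19 log units; within the scatter) from compound 2 to compound 4, 1.6-fold (0.21 log units) apart, within the scatter of two such steps. Going by these compounds alone, this agreement is compatible with the change carrying across the two cores, but it does not prove that it does, since it rests on only two pairs, only the step to compound 1 lies beyond the scatter, and the core and the place of the hydroxy vary together, so that neither can be judged separately.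

The compounds shown leave open whether an amine or a carboxylic acid in place of the methyl would give steps that agree in the same way on these two cores. They also leave open whether the hydroxy step would hold if the ethyl group on the shared core gave way to a longer chain.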